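The source may report more compounds than this note shows. Statements on the series, on what has been measured and on what is new or still open speak of the compounds shown alone.

Measured compounds:
compound 1 `Cc1ccc2c(C3CCN(CCN4CCN(C(C)C)C4=O)CC3)cn(-c3ccc(F)cc3)c2c1` gives 85 nM in an assay on cell membranes for displacement of a labelled ligand from Adrenergic receptor alpha-1 (Rattus norvegicus); a higher number here means a weaker inhibitor, a lower number a stronger inhibitor;
compound 2 `Cc1ccc2c(C3CCN(CCN4CCN(C(C)C)C4=O)CC3)c[nH]c2c1` gives 27 nM.

Compound 2 has the lowest of the two numbers in this assay. Compound 3 `Cc1ccc2c(C3CCN(CCN4CCN(C(C)C)C4=O)CC3)cn(-c3ccc(Cl)cc3)c2c1` differs from it by 4-chlorophenyl in place of hydrogen on an aromatic nitrogen. Among the compounds with values here, the one step that bears on this is a 3.1-fold lower number from compound 1 to compound 2 (0.50 log units; beyond the scatter), where removing a 4-fluorophenyl from the same aromatic nitrogen lowered the number by a modest amount. Putting a 4-chlorophenyl back in the same place is expected to reverse that, giving a step of about a 3.1-fold higher number from compound 2 to compound 3 (0.50 log units; beyond the scatter). Compound 3 is therefore expected to show around 85 nM, with a likely range from 35 nM to 220 nM.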

Compound 3, half-maximal inhibitory concentration: 450 nM
Compound 3: middle estimate off by 5.3-fold (0.72 log units), on the low side; measured number above the stated range.
By their numbers in this assay, from the lowest: compound 2; then compound 1; then compound 3.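

Placing 4-chlorophenyl in place of hydrogen on the aromatic nitrogen gives a 17-fold higher number from compound 2 to compound 3 (1.22 log units; beyond the scatter) in this assay, so a ring at this position can cost far more than the earlier pair suggested. The halogen on that ring also matters: chloro in place of fluoro gives a 5.3-fold higher number from compound 1 to compound 3 (0.72 log units; beyond the scatter), so one atom far out on the added ring changes the number beyond the scatter. Nothing available explains this difference. From the compounds shown here alone, how an unsubstituted phenyl, a 4-methoxyphenyl or a simple methyl on this nitrogen would compare remains open.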